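From isopropyl to 4-methylphenyl on compound 2

A few compounds are considered here, and "the series" means these few. Any claim that something is new, unique, unknown or untested is made for them only; others in the source may bear on it.

Compound 1 (`O=C1COc2ccc(-c3cnc(Cl)c(NS(=O)(=O)c4ccc(F)cc4)c3)cc2N1C1CCCCC1`): > 40000 nM, a limit
Compound 2 (`CC(C)N1C(=O)COc2ccc(-c3cccc(NS(=O)(=O)c4ccc(F)cc4)c3)cc21`): 26000 nM
Compound 3 (`O=C1COc2ccc(-c3cnc(Cl)c(NS(=O)(=O)c4ccc(F)cc4)c3)cc2N1c1ccccc1`): > 40000 nM, a limit

All three compounds were tested in a functional assay on MCF7 cells (Homo sapiens) for antiproliferative activity, read by MTT assay, with a stated time of 72 h; a higher number here means a weaker inhibitor, a lower number a stronger inhibitor. For the measured compounds named here, compound 2 is the only one with an actual number, 26000 nM. The other two results are limits rather than numbers, and they stand at the limit of > 40000 nM in this assay, at which 2 of the 3 values shown sit.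

Compound 4 (`Cc1ccc(N2C(=O)COc3ccc(-c4cccc(NS(=O)(=O)c5ccc(F)cc5)c4)cc32)cc1`) has not yet been measured. Going by the values given here, it carries 4-methylphenyl in place of isopropyl on an amide-type nitrogen in a ring, the single change from its neighbour: 4-methylphenyl in place of isopropyl on an amide-type nitrogen in a ring.

The closest measured change is phenyl in place of cyclohexyl on the same kind of nitrogen, and it is a step that the two limits leave unreadable from compound 1 to compound 3. It offers neither a size nor a direction to borrow, and both of its compounds also differ from compound 2 elsewhere in the structure. With no readable step to guide the forecast, no shift beyond the usual scatter is expected in this assay, so the best anchor is compound 2 at 26000 nM. The expected change is a 1.2-fold higher number from compound 2 to compound 4 (0.06 log units; within the scatter). A result reported only as a limit would not be a surprise. For compound 4 the estimated value is 30000 nM, with an expected range of 12000 nM to 70000 nM.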

Compound 4, half-maximal inhibitory concentration: 32100 nM
For compound 4 the middle estimate is 1.1-fold (0.03 log units) below the measured one, within the range that was stated.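

In this assay, placing 4-methylphenyl where isopropyl stood, on the amide-type nitrogen in a ring, gives a 1.2-fold higher number from compound 2 to compound 4 (0.09 log units; within the scatter), so the two compounds cannot be told apart. For the compounds shown here, this is the first readable comparison at this kind of nitrogen, and it shows that, in this one pair, an aromatic ring can replace a small open chain with no shift beyond the scatter. The earlier step on this kind of nitrogen, from compound 1 to compound 3, cannot be read, and the shared ceiling of the assay leaves only this pair with two real numbers: the limit of > 40000 nM in this assay, at which 2 of the 4 values shown sit.

The compounds shown leave open whether a group of a different kind on this nitrogen, such as a chain ending in an amine or a carboxylic acid, would move the result beyond the scatter. They also leave open how much of the limits of compound 1 and compound 3 comes from the nitrogen group and how much from their other difference from compound 2, since no pair shown changes that other place alone.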